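This account rests on a few compounds, and the source may have more. Where it says the series, first, only, none or still open, it means among the compounds named here.

Measured so far:
compound 1 `CC1CC(C(=O)N2CCc3nc(C#Cc4ccccc4)sc3C2)C1` — 81 nM
compound 2 `O=C(C1CC(F)(F)C1)N1CCc2nc(C#Cc3cccc(F)c3)sc2C1` — 2.5 nM

Among the measured compounds shown here, in an assay on HEK293 cells for positive allosteric modulation of metabotropic glutamate receptor 5 (Homo sapiens), read by FLIPR, with a stated time of 1 h (on this read-out lower numbers stand for an effect already at smaller amounts and higher numbers for an effect only at larger amounts of compound), compound 1 gives the higher of the two numbers, and compound 2 gives 2.5 nM, a value far enough below to stand outside the scatter; the two structures differ in more than one place, so no single step is drawn between them. Compound 3 `N#Cc1cccc(C(=O)N2CCc3nc(C#Cc4ccccc4)sc3C2)c1` is not yet measured. It differs from compound 1 by 3-cyanophenyl in place of 3-methylcyclobutyl on a carbonyl carbon. For the measured compounds named here, with no single-change step in hand, the expected step of a 1.6-fold lower number from compound 1 to compound 3 (0.21 log units; within the scatter) is small and may sit within the scatter. Compound 3 is estimated at 50 nM, range 10 nM to 250 nM.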

Compound 3, half-maximal effective concentration: 71 nM
Beside the measured number, compound 3's estimate is 1.4-fold (0.15 log units) below it, within the range that was stated.
By their numbers in this assay, from the lowest: compound 2; then compounds 3 and 1 (each within the scatter of the next).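

In this assay, on a carbonyl carbon whose other neighbour is an amide-type nitrogen in a ring, the series gives its first single-place comparison: 3-cyanophenyl in place of 3-methylcyclobutyl is a 1.1-fold lower number from compound 1 to compound 3 (0.06 log units; within the scatter) on the core of compound 1. A six-membered aromatic ring carrying a nitrile and a four-membered non-aromatic ring therefore read alike at this place.

Open, from the compounds shown here alone, is whether an unsubstituted phenyl, a primary amine or a longer alkyl chain on this carbonyl carbon would read alike too. No evidence on hand bears on this result.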